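This account rests on a few compounds, and the source may have more. Where it says the series, first, only, none or still open, it means among the compounds named here.

In an ADME assay on HEK-293T cells (Homo sapiens) for cytotoxicity, read by MTT assay, with a stated time of 72 h (a lower number here means a stronger inhibitor, a higher number a weaker inhibitor), compound 1 `CC1(C)[C@@H]2CC[C@@]1([C@H](O)CN1CCN(c3ccccc3F)CC1)C(=O)C2` gives 120000 nM; compound 3 `CC1(C)[C@@H]2CC[C@@]1([C@@H](O)CN1CCCCC1)C(=O)C2` gives 143000 nM and compound 2 `CC1CCN(C[C@H](O)[C@]23CC[C@H](CC2=O)C3(C)C)CC1` gives 158000 nM, and the gaps from compound 1 to either of them are within the scatter, so compound 1 stands with them rather than apart. Compound 4 `CC1(C)[C@@H]2CC[C@@]1([C@H](O)CN1CCN(c3ccc(Cl)cc3)CC1)C(=O)C2` differs from compound 1 by 4-chlorophenyl in place of 2-fluorophenyl on an amine nitrogen in a ring. None of the measured steps touches this aromatic group: the only one-place step shown, a 1.1-fold lower number from compound 2 to compound 3 (0.04 log units; within the scatter), concerns a saturated ring on the far side of the molecule and does not move the number beyond the scatter. Among the compounds with values here, nothing among the measured compounds therefore argues for a shift in this assay in either direction, and an unmeasured aryl exchange of this kind is given no weight on its own. The account thus expects the step of no change at the digits printed from compound 1 to compound 4 (within the scatter) to stay within the scatter, and compound 4 is estimated at 120000 nM, with a range from 55000 nM to 260000 nM.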

Compound 4, half-maximal inhibitory concentration: 9200 nM
Beside the measured number, compound 4's estimate is 13-fold (1.12 log units) above it; the measured number lies below the stated range.
By their numbers in this assay, from the lowest: compound 4; then compounds 1, 3 and 2 (each within the scatter of the next).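

In this assay, the aryl group on the amine nitrogen in a ring proves to be a place where the number can move beyond the scatter: 4-chlorophenyl in place of 2-fluorophenyl, on an otherwise unchanged core, gives a 13-fold lower number from compound 1 to compound 4 (1.12 log units; beyond the scatter) and sets compound 4 apart from the others. The only earlier step, a 1.1-fold lower number from compound 2 to compound 3 (0.04 log units; within the scatter) at a saturated ring carbon, had shown no such movement. Nothing measured here accounts for the size of the new step.

The change alters both the halogen and its place on the phenyl ring at once, so the compounds shown cannot say which of the two goes with the step. A 4-fluorophenyl or a 2-chlorophenyl group would separate them, while plain phenyl or 4-methoxyphenyl would show whether any halogen is needed at all.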